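Chloropyrazole amide replaces pyrazolylmethyl acetamide on thienopyran core

The source may hold more compounds than are shown below. What is called first, only, known or untested is meant among the compounds shown, and "the series" means these compounds.

Measured so far in an assay on cells for positive allosteric modulation of Cystic fibrosis transmembrane conductance regulator variant F508del (Homo sapiens), with stated times of 10 min and 7 s, in the presence of a further agent that is not named here; on this read-out lower numbers stand for an effect already at smaller amounts and higher numbers for an effect only at larger amounts of compound:
compound 1 `Cc1ccc(C(=O)Nc2sc3c(c2C(N)=O)CCOC3)s1` gives 778 nM;
compound 2 `CC1Cc2c(sc(NC(=O)c3ccccc3O)c2C(N)=O)C(C)O1` gives 4 nM;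
compound 3 `CC1(C)Cc2c(sc(NC(=O)Cc3ccn[nH]3)c2C(N)=O)C(C)(C)O1` gives 136 nM.

Compound 3 holds the second highest number of the three: compound 1 lies higher and compound 2 lies lower, and both gaps are beyond the usual scatter of repeated measurements. Compound 4 `CC1(C)Cc2c(sc(NC(=O)c3[nH]ncc3Cl)c2C(N)=O)C(C)(C)O1` differs from compound 3 by a group of 6 heavy atoms (3 carbon, 2 nitrogen, 1 chlorine; one five-membered aromatic ring with 2 hetero atoms) in place of a group of 6 heavy atoms (4 carbon, 2 nitrogen; one five-membered aromatic ring with 2 hetero atoms), on a carbonyl carbon. The step from compound 3 to compound 4 is expected to go downward and beyond the scatter, as a 4.5-fold lower number from compound 3 to compound 4 (0.66 log units; beyond the scatter), because compound 2, whose aromatic ring also sits on the carbonyl carbon, gives 4 nM in this assay. Compound 4 is therefore estimated at 30 nM, with a likely range from 8 nM to 150 nM.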

Compound 4, half-maximal effective concentration: 2 nM
Compound 4: middle estimate off by 15-fold (1.18 log units), on the high side, and the stated range ends above it.
By their numbers in this assay, from the lowest: compounds 4 and 2 (each within the scatter of the next); then compound 3; then compound 1.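

Replacing the (1H-pyrazol-5-yl)methyl group on the carbonyl carbon with a chlorine-bearing five-membered aromatic ring gives a 68-fold lower number from compound 3 to compound 4 (1.83 log units; beyond the scatter), although both groups have the same counts of heavy atoms, hydrogen-bond donors and acceptors. This place on the molecule is therefore highly sensitive to the group it carries, and such counts do not predict the outcome.

Two things change at once, the ring now sitting directly on the carbonyl carbon and the chlorine being added, so separating them would take the same ring without chlorine, or with bromine or a methyl group instead. No measurement at hand explains the size of this step.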